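This account rests on a few compounds, and the source may have more. Where it says the series, first, only, none or still open, it means among the compounds named here.

Measured so far in a functional assay on CCRF-CEM cells (Homo sapiens); on this read-out lower numbers stand for higher toxicity in this test and higher numbers for lower toxicity in this test:
- Compound 2 `Cc1cn([C@@H]2O[C@H](CO[Si](C)(C)C(C)(C)C)[C@@]3(OS(=O)(=O)C=C3NC(=O)c3ccccc3)[C@H]2O[Si](C)(C)C(C)(C)C)c(=O)n(C)c1=O` gives 4910 nM.
- Compound 3 `Cc1cn([C@@H]2O[C@@H]3COC4(O)CS(=O)(=O)O[C@@]34[C@H]2O[Si](C)(C)C(C)(C)C)c(=O)[nH]c1=O` gives 100000 nM.
- Compound 1 `Cc1cn([C@@H]2O[C@H](CO[Si](C)(C)C(C)(C)C)[C@@]3(OS(=O)(=O)C=C3NCCC(=O)OCc3ccccc3)[C@H]2O[Si](C)(C)C(C)(C)C)c(=O)n(C)c1=O` reaches only a limit of this assay, > 250000 nM.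

Compound 2 stands at the lowest number of the two real values; compound 3 gives a higher one. Compound 4 `Cc1cn([C@@H]2O[C@H](CO[Si](C)(C)C(C)(C)C)[C@@]3(OS(=O)(=O)C=C3NC(N)=O)[C@H]2O[Si](C)(C)C(C)(C)C)c(=O)n(C)c1=O` differs from compound 2 by amino in place of phenyl on a carbonyl carbon. Going by the values given here, the only measured step touching this part of the core is an at least 50-fold lower number from compound 1 to compound 2 (1.70 log units; beyond the scatter), where a benzoyl group entered at the amine nitrogen with a large drop. Compound 4 keeps that carbonyl but loses the phenyl, so a smaller change is expected, likely back toward higher numbers. The estimate for compound 4 is 20000 nM, between 5000 nM and 100000 nM, meaning an expected step of a 4.1-fold higher number from compound 2 to compound 4 (0.61 log units; beyond the scatter).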

Compound 4, half-maximal cytotoxic concentration: 4360 nM
Estimate against measurement, compound 4: 4.6-fold (0.66 log units) above, outside the stated range (below it).
By their numbers in this assay, from the lowest: compounds 4 and 2 (each within the scatter of the next); then compound 3. At a limit, above all of these: compound 1.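

Amino in place of phenyl on a carbonyl carbon makes no real difference in this assay: a 1.1-fold lower number from compound 2 to compound 4 (0.05 log units; within the scatter). The large step first seen with benzoyl returns with carbamoyl, so it does not depend on the phenyl ring: an at least 57-fold lower number from compound 1 to compound 4 (1.75 log units; beyond the scatter). Compound 1 marks a limit and not a number, so the true size of that step stays unknown: the limit of > 250000 nM in this assay, at which 1 of the 4 values shown sits.

From the compounds shown here alone, whether the carbonyl itself matters remains open. An acetyl group or a plain ethyl chain on the amine nitrogen would help to answer that.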